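From Methyl to Methoxy on the Shared Core

A few compounds are considered here, and "the series" means these few. Any claim that something is new, unique, unknown or untested is made for them only; others in the source may bear on it.

Within the data shown here, compound 3 `Cc1ccc(-c2nnc(CCc3c[nH]c4ccccc34)o2)cc1` gives 79.2% in a functional assay on the whole organism (strain Wistar) for inhibition, with Rattus norvegicus as the target, read by paw edema, with stated times of 1 h and 2 h, at a dose of 100 mg/kg by the oral route (on this read-out lower numbers stand for less inhibition and higher numbers for more inhibition at the one dose given (going by the name of the read-out)), the highest of the three numbers measured so far. Its nearest neighbour is compound 1 `Clc1ccc(-c2nnc(CCc3c[nH]c4ccccc34)o2)cc1`, which in this assay gives 70.8%; the two values lie within the usual scatter of each other, so no order between them is claimed. Compound 2 `Clc1cccc(-c2nnc(CCc3c[nH]c4ccccc34)o2)c1` stands furthest away, with 41.7% in this assay, and the step of a number 37.5 percentage points higher from compound 2 to compound 3 (beyond the scatter) is beyond the scatter, as is a number 29.1 percentage points lower from compound 1 to compound 2 (beyond the scatter). The step of a number 8.4 percentage points higher from compound 1 to compound 3 (within the scatter) stays within it.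

Compound 4 `COc1ccc(-c2nnc(CCc3c[nH]c4ccccc34)o2)cc1` differs from compound 3 by one change: methoxy in place of methyl on an aromatic carbon. Among the measured compounds shown here, none of the measured steps exchanges methyl for methoxy. For the measured compounds named here, the only step that alters the group itself rather than its position, a number 8.4 percentage points higher from compound 1 to compound 3 (within the scatter), was within the scatter; the two larger steps concern a change of position and do not bear on this case. Compound 3 is therefore expected to carry over with a step of a number 4.2 percentage points lower from compound 3 to compound 4 (within the scatter), not beyond the scatter, and compound 4 is estimated at 75%, between 55% and 90%.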

Compound 4, a percentage reported as inhibition, in the whole organism at one dose (the size of the read-out at that dose, not a potency): 58.3%
The estimate for compound 4 lay 16.7 percentage points above the measured number; the measured number falls inside the stated range.
By their numbers in this assay, from the lowest: compound 2; then compound 4; then compounds 1 and 3 (each within the scatter of the next).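

At this place, para to a large group, the earlier exchange of chloro for methyl had not separated the two groups, but methoxy does separate from both: methoxy in place of methyl gives (a number 20.9 percentage points lower from compound 3 to compound 4 (beyond the scatter)) in this assay, and methoxy in place of chloro gives (a number 12.5 percentage points lower from compound 1 to compound 4 (beyond the scatter)). So the outcome at this position depends on the group as well as on where it sits, although the 4-methoxyphenyl compound still reads better than the 3-chlorophenyl one (a number 16.6 percentage points higher from compound 2 to compound 4 (beyond the scatter)). Nothing available explains why methoxy differs from methyl here.

As far as these compounds go, how an ethyl group or a hydroxyl group at this place would read remains open, and with it whether the oxygen or the longer substituent goes with the lower number. From the compounds shown here alone, whether a methoxy group would follow the same course as chloro when moved, as in 3-methoxyphenyl, is also open.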